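The source may hold more compounds than are shown below. What is called first, only, known or untested is meant among the compounds shown, and "the series" means these compounds.

This study concerns how quickly the body removes a set of compounds, followed in an ADME assay on the whole organism (Rattus norvegicus, strain Sprague-Dawley) for pharmacokinetics, read by LC-MS, with a stated time of 24 h, at a dose of 1 mg/kg by the intravenous route; on this read-out lower numbers stand for slow clearance and higher numbers for fast clearance. Of the compounds shown here, two have been measured. Compound 1 `Cn1nccc1-c1cc(C(F)(F)F)ccc1[C@H]1CCc2cc(S(=O)(=O)Nc3ncccn3)ccc21` gives 4.9 mL/min/kg in this assay. Compound 2 `O=S(=O)(Nc1ncccn1)c1ccc2c(c1)OCC[C@@H]2c1ccc(C(F)(F)F)cc1-c1ccc(F)nc1` gives 2 mL/min/kg in this assay, the lowest of the two numbers; the gap to compound 1 lies beyond the scatter, so compound 2 is cleared more slowly than compound 1. These two compounds differ from each other in more than one place, so no single change can be tied to that gap.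

Compound 3 `Cn1nccc1-c1cc(C(F)(F)F)ccc1[C@H]1CCOc2cc(S(=O)(=O)Nc3ncccn3)ccc21` has not yet been measured. It keeps the core of compound 2 and differs from it in one place: 1-methyl-1H-pyrazol-5-yl in place of 6-fluoropyridin-3-yl on an aromatic carbon. The same entering group is present in compound 1, whose number in this assay is the higher of the two. Among the compounds with values here, no measured pair isolates this one change, so the expectation rests on that comparison alone. For compound 3 an estimate of 3.5 mL/min/kg is made, with a range from 1.5 mL/min/kg to 8 mL/min/kg. The expected step of a 1.8-fold higher number from compound 2 to compound 3 (0.24 log units; within the scatter) is a modest rise, likely near the edge of the scatter.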

Compound 3, clearance: 3 mL/min/kg
For compound 3 the middle estimate is 1.2-fold (0.07 log units) above the measured one, and the stated range covers the measured number.
By their numbers in this assay, from the lowest: compounds 2, 3 and 1 (each within the scatter of the next, the first and the last beyond it).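

In this assay, placing 1-methyl-1H-pyrazol-5-yl instead of 6-fluoropyridin-3-yl on this aromatic carbon, ortho to a large group and meta to a trifluoromethyl group, gives a 1.5-fold higher number from compound 2 to compound 3 (0.18 log units; within the scatter) on the same core, so on this read-out the two rings cannot be told apart at this position. Within the data shown here, the earlier compounds could not show this, since compound 1 and compound 2 differ in more than one place; this is the first pair in which the change of ring stands alone, and a six-membered ring and a five-membered ring here both leave clearance within the usual scatter of each other. No measurement shown offers an explanation for this result.

From the compounds shown here alone, what remains open is how far this position tolerates change beyond these two aromatic rings, since a carboxylic acid or an amine at the same aromatic carbon would test a very different kind of group. Going by these compounds, it is also open whether the same exchange of rings would give so small a step on a different core, as this single pair speaks only for the core of compound 2.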